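This account rests on a few compounds, and the source may have more. Where it says the series, first, only, none or still open, it means among the compounds named here.

Measured in a functional assay on HCC 2998 cells (Homo sapiens) for inhibition, read by sulforhodamine B assay, with a stated time of 48 h, tested at 10 uM; a higher number here means more inhibition of growth at the concentration tested, a lower number less inhibition of growth:
- compound 1 `COc1ccc(-c2nc3sc(-c4ccccc4)cn3n2)cc1`: 22%
- compound 2 `Clc1ccc(-c2cn3nc(-c4ccccc4)nc3s2)cc1`: 10%

Compound 2 stands lowest of the two, with compound 1 higher by a gap beyond the scatter. Compound 3 `COc1ccc(-c2nc3sc(-c4ccc(Cl)cc4)cn3n2)cc1` is still unmeasured and differs from compound 2 by methoxy in place of hydrogen on an aromatic carbon, para to a large group. Compound 1, at 22%, also carries a methoxy, so a modest rise in this assay is expected, of about the size of the scatter. The expected change is a number 8 percentage points higher from compound 2 to compound 3 (within the scatter). Compound 3 is estimated at 18%, with an expected range of 5% to 35%.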

Compound 3, percent growth inhibition at one concentration: 21.4%
Estimate against measurement, compound 3: 3.4 percentage points below; the range from low to high includes it.
By their numbers in this assay, from the lowest: compound 2; then compounds 3 and 1 (each within the scatter of the next).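

Within the data shown here, in (this assay), methoxy in place of hydrogen on an aromatic carbon, para to a large group, gives the first step at this position that can be read beyond the scatter (a number 11.4 percentage points higher from compound 2 to compound 3 (beyond the scatter)). Chloro in place of hydrogen on an aromatic carbon gives a step within the scatter, with methoxy present in both compounds (a number 0.6 percentage points lower from compound 1 to compound 3 (within the scatter)). Nothing available gives a cause for either step.

The methoxy step rests on a single pair of compounds. As far as these compounds go, whether an amine, a carboxylic acid or a longer chain such as ethoxy at this position would match methoxy remains open.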